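This account rests on a few compounds, and the source may have more. Where it says the series, first, only, none or still open, it means among the compounds named here.

Within the data shown here, in a functional assay on HCT-116 cells (Homo sapiens) for cytotoxicity, read by sulforhodamine B assay, with stated times of 4 h and 5 days (on this read-out higher numbers stand for weaker inhibition and lower numbers for stronger inhibition), compound 1 `Cc1ncc([N+](=O)[O-])n1CCS(=O)(=O)NCCO` gives 400000 nM and compound 2 `Cc1ncc([N+](=O)[O-])n1CCS(=O)(=O)NCCN(C)C` gives 800000 nM, so compound 2 stands level with the only other measured compound. Compound 3 `CCN(CC)CCNS(=O)(=O)CCn1c([N+](=O)[O-])cnc1C` differs from compound 2 in one place: diethylamino in place of dimethylamino on a saturated chain carbon, two bonds along the chain from a sulfonamide nitrogen, with diethylamino in place of dimethylamino on a saturated chain carbon, two bonds along the chain from a sulfonamide nitrogen. Among the measured compounds shown here, the single measured step at this position, dimethylamino in place of hydroxy, is a 2.0-fold higher number from compound 1 to compound 2 (0.30 log units; within the scatter). On that slim evidence, no change beyond the scatter is expected, and the estimated step is a 1.3-fold lower number from compound 2 to compound 3 (0.12 log units; within the scatter). For compound 3 the estimate is 600000 nM, with an expected range of 250000 nM to 1300000 nM.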

Compound 3, half-maximal inhibitory concentration: 1300000 nM
Beside the measured number, compound 3's estimate is 2.2-fold (0.34 log units) below it, and the stated range covers the measured number.
By their numbers in this assay, from the lowest: compounds 1, 2 and 3 (each within the scatter of the next, the first and the last beyond it).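

Diethylamino in place of dimethylamino gives a 1.6-fold higher number from compound 2 to compound 3 (0.21 log units; within the scatter), so in this assay these two amines cannot be told apart. Diethylamino in place of hydroxy gives a 3.3-fold higher number from compound 1 to compound 3 (0.51 log units; beyond the scatter), a modest move toward weaker inhibition and the first change at this position to lie beyond the scatter. Nothing available explains this difference. The compounds shown leave open whether a carboxylic acid or a morpholine at this place, or a longer chain carrying the diethylamino group, would shift the number any further.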